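Carboxymethoxy in Place of 2-Carboxyethyl on an Agonist Series

The compounds below may be only part of what the source reports. "The series", "measured", "known", "first", "only" and "open" are said of these compounds alone.

Measured compounds:
compound 1, `Cc1cc(OCc2c(-c3c(Cl)cccc3Cl)noc2C(C)C)ncc1[N+](=O)[O-]`, 1000 nM
compound 2, `CC(C)c1onc(-c2c(Cl)cccc2Cl)c1COc1ccc(NCc2ccc(C(=O)O)cc2)c(C(F)(F)F)n1`, 398 nM
compound 3, `CC(C)c1onc(-c2c(Cl)cccc2Cl)c1COc1ccc(N(C)Cc2ccc(CCC(=O)O)cc2)c(C(F)(F)F)n1`, 35 nM

The three compounds share the same isoxazole-bearing core and were tested in a functional assay on HEK293 cells for agonist activity at Bile acid receptor (Homo sapiens); a lower number here means that less compound is needed, a higher number that more compound is needed for the effect. Among them compound 3 stands at the lowest number, with 35 nM. Its nearest neighbour is compound 2, whose value is higher by a gap beyond the scatter; compound 1 lies furthest away, also beyond the scatter. Compound 3 is therefore the most potent of the three on these numbers.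

Compound 4, `CC(C)c1onc(-c2c(Cl)cccc2Cl)c1COc1ccc(N(C)Cc2ccc(OCC(=O)O)cc2)c(C(F)(F)F)n1`, has not yet been measured. It differs from compound 3 in one place: carboxymethoxy in place of 2-carboxyethyl on an aromatic carbon. The group that leaves and the group that enters are of the same size, and the change sits at the far end of the acid-bearing chain, away from the shared core. Among the measured compounds shown here, no measured pair shows this exact exchange, so its effect cannot be read off from the data at hand. The step from compound 3 to compound 4 is expected to be small, a 1.4-fold higher number from compound 3 to compound 4 (0.15 log units; within the scatter), with no direction claimed beyond the scatter. Compound 4 is accordingly estimated at 50 nM, within a range from 15 nM to 200 nM in this assay.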

Compound 4, half-maximal effective concentration: 214 nM
Compound 4: middle estimate off by 4.3-fold (0.63 log units), on the low side; the whole stated range lies below it.
By their numbers in this assay, from the lowest: compound 3; then compounds 4 and 2 (each within the scatter of the next); then compound 1.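

In this assay, exchanging 2-carboxyethyl for carboxymethoxy on the aromatic carbon gives a 6.1-fold higher number from compound 3 to compound 4 (0.79 log units; beyond the scatter), so this end of the acid-bearing chain responds to a change that leaves the heavy-atom count and the terminal carboxylic acid in place. Among the compounds shown here, the exchange replaces one carbon with an oxygen and adds a hydrogen-bond acceptor, and that alone is enough to produce a step beyond the scatter; the earlier compounds, none of which differed in only one place, could not show this. No supporting measurement is available to explain the loss, so the result records the size of the step but not its origin.

The compounds shown leave open whether a longer chain such as 3-carboxypropyl, or a carboxymethylamino group with an amine nitrogen in place of the ether oxygen, would give a number closer to that of compound 3 or to that of compound 4. They also leave open how this position would respond if a primary amide or a tetrazole replaced the carboxylic acid at the end of the chain.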